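From Diethylamino to Butoxy: Compound 1 to Compound 4

This account rests on a few compounds, and the source may have more. Where it says the series, first, only, none or still open, it means among the compounds named here.

Compound 1, `CCN(CC)c1cc(NC(=O)NNc2cc(-c3ccc(F)cc3)c3cnn(C)c3n2)cc(Cl)n1`, gives 3150 nM in an assay on isolated protein for binding affinity to sphingosine 1-phosphate receptor 2 (Homo sapiens), read by surface plasmon resonance; a higher number here means weaker binding, a lower number tighter binding.
Compound 2, `Cc1cc(NNC(=O)Nc2cc(Cl)nc(Cl)c2)nc2c1c(C)nn2C`, gives 11000 nM in this assay.
Compound 3, `Cc1ccc(NC(=O)NNc2cc(-c3ccc(F)cc3)c3cnn(C)c3n2)cc1Nc1nccc(-c2cccnc2)n1`, gives 5960 nM in this assay.

Among these three, compound 1 holds the lowest number. Compound 3 sits closest to it, and that gap lies within the scatter of repeated measurements, so the two cannot be ordered against each other. Compound 2 lies furthest away, a gap that goes beyond the scatter, so compound 1 binds more tightly than compound 2. Within the data shown here, no pair among the measured compounds differs in only one place, so no single step between measured values is available to lean on.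

Compound 4, `CCCCOc1cc(NC(=O)NNc2cc(-c3ccc(F)cc3)c3cnn(C)c3n2)cc(Cl)n1`, is the untested member. It differs from compound 1 in one place: butoxy in place of diethylamino on an aromatic carbon. Both groups carry the same number of heavy atoms, the same count of hydrogen-bond donors and acceptors and no net charge, and the rest of the shared core is untouched.

Among the measured compounds shown here, with no measured step of this kind to draw on, the change is expected to move the number little, at most modestly toward weaker binding, as a 1.3-fold higher number from compound 1 to compound 4 (0.12 log units; within the scatter). Compound 4 is therefore estimated at 4200 nM, with a plausible range from 1500 nM to 12000 nM.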

Compound 4, dissociation constant: 2650 nM
The estimate for compound 4 lay 1.6-fold (0.20 log units) above the measured number; low and high end bracket the measured number.
By their numbers in this assay, from the lowest: compounds 4, 1, 3 and 2 (each within the scatter of the next, the first and the last beyond it).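

In this assay, among these compounds, butoxy in place of diethylamino on this aromatic carbon gives a 1.2-fold lower number from compound 1 to compound 4 (0.08 log units; within the scatter), so the two compounds cannot be ordered against each other, and this is the only single-place step available in the set. It shows that, at this carbon next to the ring nitrogen, the atom joining the five-heavy-atom group to the ring can be nitrogen or oxygen without the reading moving beyond the scatter, at least for these two groups on this shared core. No other measurement here bears on why the two readings stay so close, so the step stands without an explanation.

The compounds shown leave open whether a much shorter group such as methoxy, a ring amine such as morpholine, or a carboxylic acid on this carbon would also stay within the scatter of compound 1. They also leave open whether the chloro group, kept in both compounds, could give way to a hydrogen or an amine without the number moving.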